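Carbamate in place of cyclopropylamide at the melatonin receptor

The source may report more compounds than this note shows. Statements on the series, on what has been measured and on what is new or still open speak of the compounds shown alone.

Compound 1 `CCC(=O)Nc1ccc(N(C)c2cccc(OC)c2)cc1`: 0.17 nM
Compound 2 `COc1cccc(N(C)c2ccc(NC(=O)C(C)C)cc2)c1`: 5.5 nM
Compound 3 `COc1cccc(N(C)c2ccc(NC(=O)C3CC3)cc2)c1`: 4.8 nM

The three measured compounds share one core and differ only in the group on the carbonyl carbon. In an assay on isolated protein for binding affinity to melatonin receptor type 1B (Homo sapiens) (on this read-out lower numbers stand for stronger inhibition and higher numbers for weaker inhibition), compound 1 gives the lowest number of the three; the step of a 32-fold higher number from compound 1 to compound 2 (1.51 log units; beyond the scatter) and the step of a 28-fold higher number from compound 1 to compound 3 (1.45 log units; beyond the scatter) both run to clearly higher numbers, while the step of a 1.1-fold lower number from compound 2 to compound 3 (0.06 log units; within the scatter) is within the scatter. Compound 3 therefore stands second highest of the three numbers, close to compound 2 and far from compound 1.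

Compound 4 `CCOC(=O)Nc1ccc(N(C)c2cccc(OC)c2)cc1` is not yet measured. The change is ethoxy in place of cyclopropyl on a carbonyl carbon. Within the data shown here, the steps that bear on it are those above: a branched group on the carbonyl carbon, whether isopropyl or cyclopropyl, sits well above the ethyl of compound 1, and the two branched groups do not differ. Ethoxy is an unbranched group of the same count of heavy atoms as ethyl, with an added acceptor. The prior steps give no direct read on a carbamate, so the expectation is cautious: compound 4 is estimated to give a moderately lower number than compound 3, a step of a 3.2-fold lower number from compound 3 to compound 4 (0.51 log units; beyond the scatter), with an estimate of 1.5 nM in this assay, expected to lie between 0.3 nM and 8 nM.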

Compound 4, inhibition constant: 7.2 nM
For compound 4 the middle estimate is 4.8-fold (0.68 log units) below the measured one; low and high end bracket the measured number.
By their numbers in this assay, from the lowest: compound 1; then compounds 3, 2 and 4 (each within the scatter of the next).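

In this assay, ethoxy in place of cyclopropyl on the carbonyl carbon gives a 1.5-fold higher number from compound 3 to compound 4 (0.18 log units; within the scatter), and ethoxy in place of isopropyl gives a 1.3-fold higher number from compound 2 to compound 4 (0.12 log units; within the scatter), so this carbonyl carbon accepts three quite different groups, one with a ring, one branched and one an unbranched chain carrying an oxygen, without a change that can be read. Ethoxy in place of ethyl, by contrast, gives a 42-fold higher number from compound 1 to compound 4 (1.63 log units; beyond the scatter), which shows that lacking a branch or ring does not by itself bring back the low number of compound 1: among the four compounds shown, the ethyl group alone stands apart. Nothing measured here explains why ethyl and ethoxy part so widely at this position.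

Whether the low number belongs to ethyl alone or extends to neighbouring chains stays open, since the compounds shown carry neither a methyl nor a propyl group on this carbonyl carbon. They also leave open how a methoxy or a methylamino group would behave there, and so whether the oxygen of ethoxy or its longer chain accounts for the gap.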